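Hydroxy for Chloro: What to Expect of Compound 4

The source may report more compounds than this note shows. Statements on the series, on what has been measured and on what is new or still open speak of the compounds shown alone.

Compound 1 `COc1cc(OC)c(OC)cc1/C=C/C(=O)c1ccc(Cl)cc1` was tested in a functional assay on SW982 cells (Homo sapiens) for inhibition, read by MTT assay, with a stated time of 72 h (a higher number here means a weaker inhibitor, a lower number a stronger inhibitor), where compound 1 gives 58500 nM. Of the two compounds with a number in this assay, compound 1 sits at the higher one; its nearest neighbour is compound 3 `COc1cc(OC)c(OC)cc1/C=C/C(=O)c1ccc(Cl)c([N+](=O)[O-])c1`, which in this assay gives 20600 nM. Among the compounds with values here, the single measured step between neighbours is a 2.8-fold lower number from compound 1 to compound 3 (0.45 log units; beyond the scatter). Compound 2 `COc1cc(OC)c(-c2cc(=O)c3ccc(O)cc3o2)cc1OC` belongs to the same set, but in this assay compound 2 reaches only a limit, > 150000 nM; as the limit of > 150000 nM in this assay, at which 1 of the 3 values shown sits, records, one of the three values shown sits at that limit.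

The compound still to be measured is compound 4 `COc1cc(OC)c(OC)cc1/C=C/C(=O)c1ccc(O)cc1`. It differs from compound 1 by hydroxy in place of chloro on an aromatic carbon. Within the data shown here, no measured step bears on this exchange: the only known step concerns nitro in place of hydrogen, so it offers no guide to trading chloro for hydroxy. The expectation therefore rests on compound 1 alone, and no step beyond the scatter is expected in either direction. Compound 4 is estimated to give about 75000 nM in this assay, with a likely range from 30000 nM to 190000 nM. That estimate amounts to an expected step of a 1.3-fold higher number from compound 1 to compound 4 (0.11 log units; within the scatter), within the scatter.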

Compound 4, half-maximal inhibitory concentration: 155000 nM
Compound 4: middle estimate off by 2.1-fold (0.32 log units), on the low side; low and high end bracket the measured number.
By their numbers in this assay, from the lowest: compound 3; then compound 1; then compound 4.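

On the aromatic carbon para to a large group, chloro and hydroxy are not interchangeable: the exchange gives a 2.6-fold higher number from compound 1 to compound 4 (0.42 log units; beyond the scatter) in this assay, so the number responds to what sits at this position. Read with the other measured step, a 2.8-fold lower number from compound 1 to compound 3 (0.45 log units; beyond the scatter), this shows that changes on the ring carrying the chloro can move the number in either direction, although both steps are modest and they involve different changes. Compound 2 stands only as a limit, not a number, and the number for compound 4 lies in the same high region of the scale: the limit of > 150000 nM in this assay, at which 1 of the 4 values shown sits.

The compounds shown cannot separate the loss of chloro from the gain of hydroxy, so it remains unclear which of the two drives the step. An amine, a carboxylic acid or a fluoro group at the same position would show whether the higher number is particular to hydroxy or also appears with other groups in place of chloro.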